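A Third Methoxy Group: What Compound 4 May Tolerate

The source may hold more compounds than are shown below. What is called first, only, known or untested is meant among the compounds shown, and "the series" means these compounds.

Compound 3 `COc1ccc(/C=C/C(=O)c2ccccc2OCC(=O)NCCNc2ccnc3cc(Cl)ccc23)cc1OC` gives 5310 nM in an ADME assay on Vero cells (Chlorocebus sabaeus) for cytotoxicity, read by MTT assay, with a stated time of 72 h (a higher number here means that more compound is tolerated, a lower number that less compound is tolerated), the second highest of the three numbers measured. Compound 1 `O=C(COc1ccccc1C(=O)/C=C/c1ccc(Cl)cc1)NCCNc1ccnc2cc(Cl)ccc12` gives 4980 nM, and the step of a 1.1-fold higher number from compound 1 to compound 3 (0.03 log units; within the scatter) lies within the scatter. Compound 2 `COc1ccc(/C=C/C(=O)c2ccccc2OCC(=O)NCCNc2ccnc3cc(Cl)ccc23)cc1` gives 25000 nM; the steps of a 5.0-fold higher number from compound 1 to compound 2 (0.70 log units; beyond the scatter) and a 4.7-fold lower number from compound 2 to compound 3 (0.67 log units; beyond the scatter) are both modest but beyond the scatter.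

Compound 4 `COc1cc(/C=C/C(=O)c2ccccc2OCC(=O)NCCNc2ccnc3cc(Cl)ccc23)cc(OC)c1OC` differs from compound 3 by methoxy in place of hydrogen on an aromatic carbon. For the measured compounds named here, the one measured step of the same kind, a 4.7-fold lower number from compound 2 to compound 3 (0.67 log units; beyond the scatter), lowered the number modestly, so a smaller lowering, possibly within the scatter, is expected in this assay. Compound 4 is therefore estimated at 3500 nM, with a range from 1400 nM to 9000 nM, which amounts to an expected step of a 1.5-fold lower number from compound 3 to compound 4 (0.18 log units; within the scatter).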

Compound 4, half-maximal cytotoxic concentration: 3920 nM
Compound 4: the middle estimate sits 1.1-fold (0.05 log units) below what was measured; the measured number falls inside the stated range.
By their numbers in this assay, from the lowest: compounds 4, 1 and 3 (each within the scatter of the next); then compound 2.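

In this assay the change from 3,4-dimethoxyphenyl to 3,4,5-trimethoxyphenyl gave a 1.4-fold lower number from compound 3 to compound 4 (0.13 log units; within the scatter) and so stayed within the scatter, unlike the earlier methoxy step from compound 2 to compound 3, which went beyond it. The full change from 4-methoxyphenyl remains a 6.4-fold lower number from compound 2 to compound 4 (0.80 log units; beyond the scatter) while the comparison with the 4-chlorophenyl group gives a 1.3-fold lower number from compound 1 to compound 4 (0.10 log units; within the scatter) and so shows no separation. No measurement shown here accounts for these steps. As far as these compounds go, whether an amine or a hydroxy group at this same position would also stay within the scatter remains open.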